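The compounds below may be only part of what the source reports. "The series", "measured", "known", "first", "only" and "open" are said of these compounds alone.

Measured compounds:
compound 1 `Cc1ccc(CN2CCc3c(c(=O)n(CC4NCCc5ccccc54)c(=O)n3Cc3c(F)cccc3F)C2)c(C)c1` — 95%
compound 2 `NC(CC1CCCCC1)Cn1c(=O)c2c(n(Cc3c(F)cccc3F)c1=O)CCN(Cc1ccc(Cl)cc1)C2` — 66%
compound 3 `O=c1c2c(n(Cc3c(F)cccc3F)c(=O)n1CCN1CCc3ccccc3C1)CCN(CC1CCCC1)C2` — 16%

Three compounds sharing one core were tested in an assay on isolated protein for inhibition of Gonadotropin-releasing hormone receptor (Homo sapiens), tested at 10 uM; on this read-out lower numbers stand for less inhibition and higher numbers for more inhibition at the one concentration tested (going by the name of the read-out). Compound 1 gives 95% and stands at the top of the three numbers: compound 2, with 66%, lies below it by a margin beyond the usual scatter, and compound 3, with 16%, lies further below, also beyond the scatter. No pair among these three differs in only one place, so no single-point step can be read from them.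

Compound 4 `Cc1ccc(CN2CCc3c(c(=O)n(CC4CCNCC4)c(=O)n3Cc3c(F)cccc3F)C2)c(C)c1` has not been measured. It differs from compound 1 in one place: piperidin-4-yl in place of 1,2,3,4-tetrahydroisoquinolin-1-yl on a saturated chain carbon bound to an aromatic nitrogen. For the measured compounds named here, since the measured compounds give no step for a change of this kind, the expectation rests on compound 1 alone, with the spread of the other two values as a caution. The inhibition of compound 4 in this assay is expected to fall below that of compound 1, with a number 40 percentage points lower from compound 1 to compound 4 (beyond the scatter) as the expected step, beyond the scatter. Compound 4 is estimated at 55%, within a range of 20% to 85%.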

Compound 4, a percentage reported as inhibition, at one concentration (the size of the read-out at that concentration, not a potency): 72%
Compound 4: middle estimate off by 17 percentage points, on the low side; the measured number falls inside the stated range.
By their numbers in this assay, from the lowest: compound 3; then compounds 2 and 4 (each within the scatter of the next); then compound 1.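

In this assay this position gives its first single-place step, as piperidin-4-yl replaces 1,2,3,4-tetrahydroisoquinolin-1-yl with a number 23 percentage points lower from compound 1 to compound 4 (beyond the scatter) and compound 4 still gives 72% at the one concentration tested. The entering group keeps the six-membered non-aromatic ring and the same counts of hydrogen-bond donors and acceptors, but it has fewer heavy atoms and no six-membered aromatic ring. Nothing measured here explains the step.

This single pair cannot separate the loss of the aromatic ring from the loss of heavy atoms. From the compounds shown here alone, how piperidin-3-yl or an open-chain primary amine would read on the same saturated chain carbon remains open, as does whether the step holds on the other groups seen around the shared core.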